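The source may hold more compounds than are shown below. What is called first, only, known or untested is meant among the compounds shown, and "the series" means these compounds.

Measured in a functional assay on MDA-MB-231 cells (Homo sapiens) for cytotoxicity, read by MTT assay, with a stated time of 48 h; on this read-out higher numbers stand for weaker inhibition and lower numbers for stronger inhibition:

- Compound 1 `Cc1ccc(NC(=O)NCCCCC(c2ccc(F)cc2)c2ccc(F)cc2)cc1`: > 20000 nM, a limit of the assay.
- Compound 2 `O=C(NCCCCC(c1ccc(F)cc1)c1ccc(F)cc1)Nc1cccc(C(F)(F)F)c1`: 3380 nM.
- Compound 3 `O=C(NCCCCC(c1ccc(F)cc1)c1ccc(F)cc1)Nc1cccc(Cl)c1`: 5070 nM.

Within the data shown here, compound 3 has only one exact number to stand against, and chloro in place of trifluoromethyl gave a 1.5-fold higher number from compound 2 to compound 3 (0.18 log units; within the scatter). Replacing 4-methylphenyl gave larger steps, an at least 3.9-fold lower number from compound 1 to compound 3 (0.59 log units; beyond the scatter) and an at least 5.9-fold lower number from compound 1 to compound 2 (0.77 log units; beyond the scatter).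

Compound 4 `O=C(NCCCCC(c1ccc(F)cc1)c1ccc(F)cc1)Nc1cccc([N+](=O)[O-])c1` carries the change nitro in place of chloro on an aromatic carbon, meta to a large group. Among the measured compounds shown here, the closest precedent is the exchange at this same place, which stayed within the scatter, so no step beyond the scatter is expected in this assay. The estimated change is a 1.1-fold higher number from compound 3 to compound 4 (0.04 log units; within the scatter). For compound 4 the expected value is 5500 nM, with an estimated range of 2200 nM to 14000 nM.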

Compound 4, half-maximal inhibitory concentration: 3790 nM
The estimate for compound 4 lay 1.5-fold (0.16 log units) above the measured number; the range from low to high includes it.
By their numbers in this assay, from the lowest: compounds 2, 4 and 3 (each within the scatter of the next). At a limit, above all of these: compound 1.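

Nitro at this position sits with chloro and trifluoromethyl, so a third group leaves the number within the scatter (a 1.3-fold lower number from compound 3 to compound 4 (0.13 log units; within the scatter)) and (a 1.1-fold higher number from compound 2 to compound 4 (0.05 log units; within the scatter)). Like those two groups, 3-nitrophenyl differs clearly from 4-methylphenyl (an at least 5.2-fold lower number from compound 1 to compound 4 (0.72 log units; beyond the scatter)). That step is only a bound, set by the limit of compound 1: (the limit of > 20000 nM in this assay, at which 1 of the 4 values shown sits). The compounds shown leave open whether an amine or a carboxylic acid at this position would also stay within the scatter. As far as these compounds go, a shorter or longer chain in the shared core also remains open.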